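From methoxymethyl to pyridin-3-yl: a half-life estimate for compound 4

The source may hold more compounds than are shown below. What is called first, only, known or untested is meant among the compounds shown, and "the series" means these compounds.

In an in vitro ADME assay on microsomes from liver (Rattus norvegicus) for metabolic stability (on this read-out higher numbers stand for a longer-lived compound and lower numbers for a shorter-lived compound), three compounds have numbers so far:
compound 1 `Cc1nc2ccc(-c3ccccc3Cl)c(CN)c2n1C` gives 0.117 h
compound 2 `NCc1c(-c2ccc(Cl)cc2Cl)ccc2nc[nH]c12` gives 0.767 h
compound 3 `COCc1nc2ccc(-c3ccccc3Cl)c(CN)c2n1C` gives 0.183 h

Compound 3 at 0.183 h lies within the scatter of compound 1 at 0.117 h. Compound 2 at 0.767 h stands clearly higher on this scale than compound 3, beyond the scatter. Compound 4 `Cn1c(-c2cccnc2)nc2ccc(-c3ccccc3Cl)c(CN)c21` has not yet been measured. It carries pyridin-3-yl in place of the methoxymethyl of compound 3 on an aromatic carbon (pyridin-3-yl in place of methoxymethyl on an aromatic carbon). Within the data shown here, only one measured step bears on this place: a 1.6-fold higher number from compound 1 to compound 3 (0.19 log units; within the scatter) with methoxy in place of hydrogen on a saturated chain carbon bound to an aromatic carbon. Among the measured compounds shown here, no measured compound carries an aromatic ring there, so that small step is thin guidance and points to no direction. The expected step is a 1.1-fold lower number from compound 3 to compound 4 (0.03 log units; within the scatter) and it is not expected to leave the scatter. In this assay the estimated value for compound 4 is 0.17 h with 0.08 h to 0.4 h as the expected range.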

Compound 4, half-life: 0.433 h
Beside the measured number, compound 4's estimate is 2.5-fold (0.41 log units) below it; the whole stated range lies below it.
By their numbers in this assay, from the lowest: compounds 1 and 3 (each within the scatter of the next); then compounds 4 and 2 (each within the scatter of the next).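

In this assay the aromatic carbon between two ring nitrogen atoms proves responsive: pyridin-3-yl in place of methoxymethyl gives a 2.4-fold higher number from compound 3 to compound 4 (0.37 log units; beyond the scatter) whereas the earlier change at this place gave only a 1.6-fold higher number from compound 1 to compound 3 (0.19 log units; within the scatter). Set against the methyl group, the same pyridin-3-yl gives a 3.7-fold higher number from compound 1 to compound 4 (0.57 log units; beyond the scatter) so both steps to this aromatic ring lie beyond the scatter, and the ring is the first group at this place to separate clearly from the others. Nothing measured here gives a reason for this rise.

Going by these compounds, it remains open whether a plain phenyl group or pyridin-4-yl at this place would give a similar half-life, a comparison that would separate the ring itself from the place of its nitrogen. Also open, on these data alone, is how a saturated ring such as piperidine would compare.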